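Compound 3 to its methoxy analogue

The source may hold more compounds than are shown below. What is called first, only, known or untested is meant among the compounds shown, and "the series" means these compounds.

Measured in an ADME assay on L02 cells (Homo sapiens) for inhibition, read by CCK-8 assay, with a stated time of 48 h; on this read-out lower numbers stand for stronger inhibition of growth and higher numbers for weaker inhibition of growth:
- compound 1 `CN1CCN(c2ccc(Nc3ncc(Cl)c(NCc4ccc(C(F)(F)F)cc4)n3)nc2)CC1` gives 26200 nM
- compound 2 `CN1CCN(c2ccc(Nc3ncc(Cl)c(NCc4ccco4)n3)nc2)CC1` gives 45700 nM
- compound 3 `CC(C)c1cccc(Nc2nc(Nc3ccc(N4CCN(C)CC4)cn3)ncc2Cl)c1` gives 12500 nM

Compound 3 holds the lowest of these numbers. Compound 1 and compound 2 show no separation beyond the scatter: a 1.7-fold higher number from compound 1 to compound 2 (0.24 log units; within the scatter). Compound 4 `COc1cccc(Nc2nc(Nc3ccc(N4CCN(C)CC4)cn3)ncc2Cl)c1` carries methoxy in place of isopropyl on an aromatic carbon, meta to a large group. For the measured compounds named here, no measured step changes this group alone. The closest evidence is a 2.1-fold lower number from compound 1 to compound 3 (0.32 log units; beyond the scatter) and a 3.7-fold lower number from compound 2 to compound 3 (0.56 log units; beyond the scatter), each replacing the whole group on a nitrogen on an aromatic ring. A smaller edit is therefore expected to move this assay less, with a slight lean to a higher number and nothing clearly beyond the scatter. The estimated step is a 1.4-fold higher number from compound 3 to compound 4 (0.16 log units; within the scatter). For compound 4 the expected value is 18000 nM, within an estimated range of 8000 nM to 40000 nM.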

Compound 4, concentration for 50% growth inhibition: 3470 nM
Beside the measured number, compound 4's estimate is 5.2-fold (0.71 log units) above it; measured number outside the range, below it.
By their numbers in this assay, from the lowest: compound 4; then compound 3; then compounds 1 and 2 (each within the scatter of the next).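

In this assay the edit at this aromatic carbon, meta to a large group, is enough on its own to move the number beyond the scatter (a 3.6-fold lower number from compound 3 to compound 4 (0.56 log units; beyond the scatter)). The 3-methoxyphenyl group also separates clearly from the two groups on the nitrogen that hold a saturated chain carbon (a 13-fold lower number from compound 2 to compound 4 (1.12 log units; beyond the scatter); a 7.6-fold lower number from compound 1 to compound 4 (0.88 log units; beyond the scatter)). No available data account for the methoxy step.

On these data alone, whether the lower number goes with the oxygen or with the smaller group stays open. Ethoxy or hydroxy at this place could help separate the two.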